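A Chloro Substituent Enters the Benzyl Ring of Compound 1

A few compounds are considered here, and "the series" means these few. Any claim that something is new, unique, unknown or untested is made for them only; others in the source may bear on it.

Compound 1 `COc1cc(OC)c(-c2coc3cc(OCc4ccccc4)ccc3c2=O)cc1OC` stands second highest of the three numbers recorded in a functional assay on B16 cells (Mus musculus) for antiproliferative activity, read by MTT assay, with a stated time of 24 h (a higher number here means a weaker inhibitor, a lower number a stronger inhibitor), where compound 1 gives 2330 nM. Its nearest neighbour is compound 2 `COc1cc(OC)c(-c2coc3cc(OCc4ccc(Br)cc4)ccc3c2=O)cc1OC`, which in this assay gives 1180 nM; the step of a 2.0-fold lower number from compound 1 to compound 2 (0.30 log units; within the scatter) lies within the scatter. Furthest is compound 3 `COc1cc(OC)c(-c2coc3cc(OCc4ccc(C#N)cc4)ccc3c2=O)cc1OC`, which in this assay gives 7000 nM; the step of a 3.0-fold higher number from compound 1 to compound 3 (0.48 log units; beyond the scatter) is modest but beyond the scatter, and a 5.9-fold higher number from compound 2 to compound 3 (0.77 log units; beyond the scatter) points the same way.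

Compound 4 `COc1cc(OC)c(-c2coc3cc(OCc4ccc(Cl)cc4)ccc3c2=O)cc1OC` differs from compound 1 by chloro in place of hydrogen on an aromatic carbon. The measured step that bears most directly is a 2.0-fold lower number from compound 1 to compound 2 (0.30 log units; within the scatter), for bromo, like chloro, is a halogen, and compound 2 bears bromo where compound 4 bears chloro; that step stayed within the scatter. The cyano steps ran the other way, but cyano is not a halogen. A step in this assay of about a 1.6-fold lower number from compound 1 to compound 4 (0.19 log units; within the scatter) is therefore expected for compound 4, within the scatter or only marginally beyond it. Compound 4 is estimated to give 1500 nM in this assay, with a range from 700 nM to 3500 nM.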

Compound 4, half-maximal inhibitory concentration: 2400 nM
For compound 4 the middle estimate is 1.6-fold (0.20 log units) below the measured one; the measured number falls inside the stated range.
By their numbers in this assay, from the lowest: compounds 2, 1 and 4 (each within the scatter of the next, the first and the last beyond it); then compound 3.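

In this assay, chloro at this carbon of the benzyl ring, para to a large group, gives a 1.0-fold higher number from compound 1 to compound 4 (0.01 log units; within the scatter) and so leaves compound 4 level with compound 1, which shows that a halogen here does not of itself reproduce the number of compound 2. The halogens can in fact be told apart at this position, since a 2.0-fold higher number from compound 2 to compound 4 (0.31 log units; beyond the scatter) is modest but beyond the scatter, even though each halogen lies within the scatter of hydrogen. Chloro also stands apart from cyano, with a 2.9-fold lower number from compound 3 to compound 4 (0.46 log units; beyond the scatter) likewise modest but beyond the scatter, so cyano remains the only change here that separates from hydrogen.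

Nothing at hand explains why bromo and chloro part at this carbon. Open too, as far as these compounds go, is how fluoro, iodo, an amine or a carboxylic acid would read at the same carbon.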